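Nitro to Methoxy on an Inactive Series

The source may report more compounds than this note shows. Statements on the series, on what has been measured and on what is new or still open speak of the compounds shown alone.

Measured in a functional assay on MCF7 cells (Homo sapiens) for antiproliferative activity, read by MTT assay, with a stated time of 72 h; on this read-out higher numbers stand for weaker inhibition and lower numbers for stronger inhibition:
- compound 1 `Cn1cc(-c2cnc3ncnc(NCc4cccc([N+](=O)[O-])c4)c3c2)cn1`: > 100000 nM
- compound 2 `CC(Nc1ncnc2ncc(-c3cnn(C)c3)cc12)c1c(Cl)ccc(F)c1Cl`: > 100000 nM

Neither entry is a true number, since each value is a limit of the assay. Together they show (the limit of > 100000 nM in this assay, at which 2 of the 2 values shown sit). As far as these compounds go, compound 1 therefore stands at that limit, and how far beyond it the real value lies remains unknown. Compound 2 stands at the same limit, so the data offer no difference in strength to learn from.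

Compound 3 `COc1cccc(CNc2ncnc3ncc(-c4cnn(C)c4)cc23)c1` keeps the shared core of compound 1 and changes one group: methoxy in place of nitro on an aromatic carbon. Methoxy takes the place of nitro on an aromatic carbon, meta to a large group, turning 3-nitrophenyl into 3-methoxyphenyl. Within the data shown here, no measured pair shows what a swap of this kind does in this assay.

The expectation therefore rests on compound 1, whose > 100000 nM is a limit. In this assay the expected step of a number no higher from compound 1 to compound 3 (the limit leaves the size open) is none beyond the usual scatter, in neither direction. For compound 3 the estimated value is 100000 nM, with an expected range from 30000 nM to 200000 nM.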

Compound 3, half-maximal inhibitory concentration: > 100000 nM
Compound 3: only a limit was reported; the forecaster's own chance of this, stated with the estimate: 75%; the middle value lies on the limit itself.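

In this assay compound 3 gives > 100000 nM, which is a limit and not a number. Among these compounds, compound 1 also sits at a limit, so no step from compound 1 to compound 3 can be read: the limit of > 100000 nM in this assay, at which 3 of the 3 values shown sit. As far as these compounds go, how far beyond that limit the real values of compound 1 and compound 3 lie, and whether methoxy and nitro differ at all, remains open.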